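Isoleucine-to-cysteine ethyl ester swap on the amine nitrogen

The source may hold more compounds than are shown below. What is called first, only, known or untested is meant among the compounds shown, and "the series" means these compounds.

Going by the values given here, in a functional assay on MCF7 cells (Homo sapiens) for inhibition, read by MTT assay, with a stated time of 3 days (a higher number here means a weaker inhibitor, a lower number a stronger inhibitor), compound 1 `CC[C@H](C)[C@H](NCC(=O)NNC(=O)COc1ccc(-c2nc3ccccc3s2)cc1OC)C(=O)O` gives 1710 nM, the lowest of the two numbers so far; the nearest is compound 2 `CCOC(=O)[C@@H](NCC(=O)NNC(=O)COc1ccc(-c2nc3ccccc3s2)cc1OC)[C@@H](C)CC` at 1950 nM, and the two lie within the scatter: a 1.1-fold higher number from compound 1 to compound 2 (0.06 log units; within the scatter). Compound 3 `CCOC(=O)[C@H](CS)NCC(=O)NNC(=O)COc1ccc(-c2nc3ccccc3s2)cc1OC` carries 1-(ethoxycarbonyl)-2-sulfanylethyl in place of 1-carboxy-2-methylbutyl on an amine nitrogen. Among the compounds with values here, only the step from compound 1 to compound 2 bears on this, covering the ester part of the change alone, and it stayed within the scatter; the side-chain part has no measured precedent. For compound 3 a step of a 1.2-fold higher number from compound 1 to compound 3 (0.07 log units; within the scatter) is expected, with an estimate of 2000 nM and a range of 800 nM to 5000 nM in this assay.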

Compound 3, half-maximal inhibitory concentration: 2880 nM
Compound 3: middle estimate off by 1.4-fold (0.16 log units), on the low side, within the range that was stated.
By their numbers in this assay, from the lowest: compounds 1, 2 and 3 (each within the scatter of the next).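

The side chain can now be read alone: sulfanylmethyl in place of sec-butyl on a saturated chain carbon bound to an amine nitrogen and a carbonyl carbon gives a 1.5-fold higher number from compound 2 to compound 3 (0.17 log units; within the scatter) in this assay, with no change beyond the scatter. The full replacement of 1-carboxy-2-methylbutyl by 1-(ethoxycarbonyl)-2-sulfanylethyl on the amine nitrogen gives a 1.7-fold higher number from compound 1 to compound 3 (0.23 log units; within the scatter) and also stays within it. No supporting data bear on the reason for this flat result.

Open, as far as these compounds go, is whether an aminomethyl or a longer alkyl chain at this carbon would move the number beyond the scatter.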